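The compounds below may be only part of what the source reports. "The series", "measured", "known", "first", "only" and "open" are said of these compounds alone.

Three compounds sharing one core were measured in an in vitro functional assay on 1321-N1 cells for agonist activity at Free fatty acid receptor 1 (Homo sapiens), read by fluorescence, spectrophotometry and calcium flux; a lower number here means that less compound is needed, a higher number that more compound is needed for the effect. Compound 1 `O=C(O)CCc1ccc(C#Cc2cccnc2)cc1` gives 6030 nM. Compound 2 `O=C(O)CCc1ccc(C#Cc2ccncc2)cc1` gives 4070 nM. Compound 3 `O=C(O)CCc1ccc(C#Cc2ccccn2)cc1` gives 13200 nM, the highest of the three numbers; its nearest neighbour is compound 1, and a 2.2-fold higher number from compound 1 to compound 3 (0.34 log units; beyond the scatter), while a 3.2-fold higher number from compound 2 to compound 3 (0.51 log units; beyond the scatter). Between the other two compounds there is a 1.5-fold lower number from compound 1 to compound 2 (0.17 log units; within the scatter). Compound 4 `O=C(O)CCc1ccc(C#Cc2cncs2)cc1` differs from compound 3 in one place: 1,3-thiazol-5-yl in place of pyridin-2-yl on a triple-bonded carbon. Within the data shown here, no measured step introduces 1,3-thiazol-5-yl, so the only guidance comes from the two steps that brought in pyridin-2-yl, namely a 2.2-fold higher number from compound 1 to compound 3 (0.34 log units; beyond the scatter) and a 3.2-fold higher number from compound 2 to compound 3 (0.51 log units; beyond the scatter), both of which raised the number. Leaving pyridin-2-yl for a different ring is therefore more likely to move the number back toward those of compound 1 and compound 2 than to raise it further, though a five-membered aromatic ring with two hetero atoms is untested in this set. Compound 4 is expected to show a 2.4-fold lower number from compound 3 to compound 4 (0.38 log units; beyond the scatter) in this assay. The estimate for compound 4 is 5500 nM, with a range from 2000 nM to 15000 nM.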

Compound 4, half-maximal effective concentration: 3890 nM
Compound 4: the middle estimate sits 1.4-fold (0.15 log units) above what was measured; the range from low to high includes it.
By their numbers in this assay, from the lowest: compounds 4, 2 and 1 (each within the scatter of the next); then compound 3.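

The change to 1,3-thiazol-5-yl gives a 3.4-fold lower number from compound 3 to compound 4 (0.53 log units; beyond the scatter) in this assay and shows that this place, on a triple-bonded carbon, accepts a five-membered aromatic ring with 2 hetero atoms as well as a six-membered one. The new ring cannot be told apart from the other two pyridines, with a 1.0-fold lower number from compound 2 to compound 4 (0.02 log units; within the scatter) and a 1.6-fold lower number from compound 1 to compound 4 (0.19 log units; within the scatter) both within the scatter, so among the four rings only pyridin-2-yl stands apart. Nothing measured here explains why pyridin-2-yl differs from the other three rings.

The compounds shown leave open whether a plain phenyl ring at this place would group with compound 3 or with the other three. They also leave open whether a methyl group or an amine on the 1,3-thiazol-5-yl ring would move the number.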